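A few compounds are considered here, and "the series" means these few. Any claim that something is new, unique, unknown or untested is made for them only; others in the source may bear on it.

Two compounds of this series have been run in an assay on isolated protein for binding affinity to Bile acid receptor (Homo sapiens), read by FRET; a higher number here means that more compound is needed for the effect, a lower number that less compound is needed. Compound 1 `CC(C)c1onc(-c2c(Cl)cccc2Cl)c1COc1ccc2nc(-c3cccc(C(=O)O)c3)sc2c1` gives 410 nM in this assay. Compound 2 `CC(C)c1onc(-c2c(Cl)cccc2Cl)c1COc1ccc2cc(-c3cccc(C(=O)O)c3)ccc2c1` carries the same acid-bearing ring on a different two-ring core and in this assay gives 110 nM, the lower of the two values; the gap between compound 1 and compound 2 lies beyond the usual scatter, so compound 2 is the stronger binder of the pair.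

Compound 3 `CC(C)c1onc(-c2c(Cl)cccc2Cl)c1COc1ccc2cc(-c3ccc(C(=O)O)cc3)ccc2c1` keeps the core of compound 2 and moves the acid within the pendant ring: 4-carboxyphenyl in place of 3-carboxyphenyl on an aromatic carbon. Within the data shown here, no step of this kind has been measured, so the expectation rests only on the standing of compound 2 and on the change itself. A modest weakening, roughly of the size seen between the two measured compounds or somewhat smaller, is estimated as the step of a 2.3-fold higher number from compound 2 to compound 3 (0.36 log units; beyond the scatter), although an outcome within the scatter cannot be excluded. In this assay compound 3 is expected to give about 250 nM, with a likely range from 90 nM to 800 nM.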

Compound 3, half-maximal effective concentration: 440 nM
Compound 3: the middle estimate sits 1.8-fold (0.25 log units) below what was measured; the range from low to high includes it.
By their numbers in this assay, from the lowest: compound 2; then compounds 1 and 3 (each within the scatter of the next).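

In this assay, among these compounds, 4-carboxyphenyl in place of 3-carboxyphenyl on the core of compound 2 gives the first single-change step: a 4.0-fold higher number from compound 2 to compound 3 (0.60 log units; beyond the scatter). The step is modest but beyond the scatter, and since the two compounds have the same atoms joined differently, the attachment of the carboxyphenyl's acid alone is enough to shift the read-out, with 3-carboxyphenyl giving the lower number on this core. Nothing available on these compounds bears on what lies behind this difference.

Still open is whether the same preference holds on the core of compound 1, for which only 3-carboxyphenyl is shown, so the effect of the acid's placement is known on a single core. Also open, from the compounds shown here alone, is how this position responds when the carboxylic acid on the pendant ring gives way to another group, such as a tetrazole or a primary amide, or when a methylene chain separates the acid from that ring.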